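Replacing an ethyl with 4-chlorophenyl on an amide carbonyl

The source may report more compounds than this note shows. Statements on the series, on what has been measured and on what is new or still open speak of the compounds shown alone.

All values here come from a functional assay on PC-3 cells (Homo sapiens) for cytotoxicity, read by sulforhodamine B assay, with a stated time of 72 h; on this read-out higher numbers stand for weaker inhibition of growth and lower numbers for stronger inhibition of growth. Compound 1 `O=C(Nc1ccccc1O)C1CCc2ccccc2N1C(=O)c1ccc(Cl)cc1` gives 25100 nM. Compound 2 `O=C(Nc1ccc(C(F)(F)F)cc1)C1CCc2ccccc2N1` gives 20300 nM; the two values lie within the usual scatter of each other, so no order between them can be read. Compound 3 `CCC(=O)N1c2ccccc2CCC1C(=O)Nc1ccccc1C(F)(F)F` stands apart from both. For compound 3 the result is not a number but a limit, > 80000 nM, and the limit of > 80000 nM in this assay, at which 1 of the 3 values shown sits, marks the edge of what the assay can report. Compound 3 therefore sits at the weak end of everything shown, without a figure of its own.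

Compound 4 `O=C(Nc1ccccc1C(F)(F)F)C1CCc2ccccc2N1C(=O)c1ccc(Cl)cc1` has not yet been measured. It differs from compound 3 in one place: 4-chlorophenyl in place of ethyl on a carbonyl carbon. Compound 1 already carries 4-chlorophenyl on the same kind of carbonyl carbon next to the ring nitrogen and gives a number, 25100 nM, rather than a limit. Among the compounds with values here, since no measured step joins compound 3 to compound 4, the size of the change can only be estimated. Compound 4 is expected to move into the measurable range, with the step of an at least 2.6-fold lower number from compound 3 to compound 4 (0.42 log units; beyond the scatter) expected to run toward stronger inhibition of growth. Compound 4 is estimated at 30000 nM, with a likely range from 10000 nM to 90000 nM.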

Compound 4, concentration for 50% growth inhibition: 786 nM
Estimate against measurement, compound 4: 38-fold (1.58 log units) above; the whole stated range lies above it.
By their numbers in this assay, from the lowest: compound 4; then compounds 2 and 1 (each within the scatter of the next). At a limit, above all of these: compound 3.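

In this assay putting 4-chlorophenyl in place of ethyl on the carbonyl carbon attached to the amide-type nitrogen in a ring gives an at least 100-fold lower number from compound 3 to compound 4 (2.00 log units; beyond the scatter) and so shows that the group at this place can decide whether growth inhibition is seen at all. On these data alone, compound 3 has only a limit and not a number, which makes this step a minimum whose true size is unknown: the limit of > 80000 nM in this assay, at which 1 of the 4 values shown sits. The 4-chlorophenyl group is still not enough on its own, since with it held fixed, trifluoromethyl in place of hydroxy on an aromatic carbon gives a 32-fold lower number from compound 1 to compound 4 (1.50 log units; beyond the scatter) and the large gain appears only when both groups are present.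

The compounds shown cannot tell whether the gain on the carbonyl comes from the six-membered aromatic ring or from its chlorine, a question that plain phenyl or a longer chain such as butyl at the same place would help to answer. As far as these compounds go, it also remains open how an amine or a carboxylic acid would fare in place of trifluoromethyl on the aromatic carbon.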